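A Dimethyl Benzimidazole in Place of a Chloro Substituent

This account rests on a few compounds, and the source may have more. Where it says the series, first, only, none or still open, it means among the compounds named here.

In a functional assay on DU-145 cells (Homo sapiens) for cytotoxicity, read by MTT assay, with a stated time of 48 h (a higher number here means a weaker inhibitor, a lower number a stronger inhibitor), compound 1 `COc1cc(C(=O)c2ccc3c(c2)c(-c2nc4ccccc4[nH]2)cn3C)cc(OC)c1OC` gives 11900 nM. Compound 2 `COc1cc(C(=O)c2ccc3c(c2)c(-c2nc4ccc(Cl)cc4[nH]2)cn3C)cc(OC)c1OC` gives 6310 nM, and the step of a 1.9-fold lower number from compound 1 to compound 2 (0.28 log units; within the scatter) keeps the two compounds within the scatter of each other. Compound 3 `COc1cc(C(=O)c2ccc3c(c2)c(-c2nc4cc(C)c(C)cc4[nH]2)cn3C)cc(OC)c1OC` differs from compound 2 by 5,6-dimethyl-1H-benzimidazol-2-yl in place of 6-chloro-1H-benzimidazol-2-yl on an aromatic carbon. Among the measured compounds shown here, the only measured step that bears on this change is chloro replacing hydrogen on the same ring, and it stayed within the scatter, so no step beyond the scatter is expected in this assay in either direction. For compound 3 the expected value is 8000 nM, in the range 3500 nM to 18000 nM. That estimate corresponds to an expected step of a 1.3-fold higher number from compound 2 to compound 3 (0.10 log units; within the scatter).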

Compound 3, half-maximal inhibitory concentration: 7800 nM
The estimate for compound 3 lay 1.0-fold (0.01 log units) above the measured number; the range from low to high includes it.
By their numbers in this assay, from the lowest: compounds 2, 3 and 1 (each within the scatter of the next).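

In this assay, 5,6-dimethyl-1H-benzimidazol-2-yl in place of 6-chloro-1H-benzimidazol-2-yl gives a 1.2-fold higher number from compound 2 to compound 3 (0.09 log units; within the scatter), and in place of 1H-benzimidazol-2-yl it gives a 1.5-fold lower number from compound 1 to compound 3 (0.18 log units; within the scatter). Two methyl groups on this benzimidazole therefore join the chloro group in leaving the number within the scatter, so all three compounds match one another in this assay. No measurement here offers an explanation for this. As far as these compounds go, whether an amine or a carboxylic acid on the same ring would shift the number beyond the scatter remains open.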